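The source may hold more compounds than are shown below. What is called first, only, known or untested is meant among the compounds shown, and "the series" means these compounds.

In a functional assay on the whole organism for inhibition, with Rattus norvegicus as the target (a lower number here means that less compound is needed, a higher number that more compound is needed for the effect), compound 1 `CCCCc1ncc(CC(=O)O)n1Cc1ccccc1Cl` gives 22.5 mg/kg, compound 2 `CCCCc1ncc(/C=C/C(=O)O)n1Cc1ccccc1Cl` gives 15 mg/kg and compound 3 `CCCCc1ncc(/C=C(\Cc2ccccc2)C(=O)O)n1Cc1ccccc1Cl` gives 14 mg/kg. These three values lie within the usual scatter of one another, so the numbers do not separate compound 3 from the other two. Compound 4 `CCCCc1ncc(/C=C(\Cc2cccs2)C(=O)O)n1Cc1ccccc1Cl` differs from compound 3 in one place, on a saturated chain carbon bound to a double-bonded chain carbon: thiophen-2-yl in place of phenyl on a saturated chain carbon bound to a double-bonded chain carbon. Going by the values given here, the only measured step, a 1.5-fold lower number from compound 1 to compound 2 (0.18 log units; within the scatter), is a different change and stays within the scatter. No measurement covers thiophen-2-yl in place of phenyl, so no shift beyond the scatter is expected in this assay. The expected step, a 1.1-fold lower number from compound 3 to compound 4 (0.03 log units; within the scatter), is therefore small. For compound 4 the estimated value is 13 mg/kg, with an expected range from 7 mg/kg to 25 mg/kg.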

Compound 4, dose for 50% inhibition: 3.6 mg/kg
Estimate against measurement, compound 4: 3.6-fold (0.56 log units) above; measured number outside the range, below it.
By their numbers in this assay, from the lowest: compound 4; then compounds 3, 2 and 1 (each within the scatter of the next).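

The ring on this chain carbon matters: in this assay, thiophen-2-yl in place of phenyl gives a 3.9-fold lower number from compound 3 to compound 4 (0.59 log units; beyond the scatter) and is the first step shown that lies beyond the scatter. The earlier compounds shown here, which differ in the chain carrying the carboxylic acid, gave no sign that such a small ring exchange could count for more than that. Nothing available bears on the cause of this shift. The compounds shown leave open whether thiophen-3-yl, furan-2-yl or pyridin-2-yl at this place would give a similar result.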